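The source may hold more compounds than are shown below. What is called first, only, known or untested is meant among the compounds shown, and "the series" means these compounds.

Measured compounds in a functional assay on HT-29 cells (Homo sapiens) for cytotoxicity, read by MTT assay, with a stated time of 72 h; on this read-out higher numbers stand for weaker inhibition and lower numbers for stronger inhibition:
compound 1 `COc1cc2c(Oc3ccc(NC(=O)c4cn(-c5ccccc5F)nn4)cc3F)ccnc2cc1OCCCN1CCC(C)CC1`, compound 1 gives 210 nM
compound 2 `COc1cc2c(Oc3ccc(NC(=O)c4cn(-c5c(Cl)cccc5Cl)nn4)cc3F)ccnc2cc1OCCCN1CCC(C)CC1`, compound 2 gives 1390 nM

For the measured compounds named here, compound 1 stands at the lowest of the two numbers recorded in this assay; the only other measured compound, compound 2, lies a clear distance above it, as a 6.6-fold higher number from compound 1 to compound 2 (0.82 log units; beyond the scatter) shows, the sole measured step in the set. That step concerns the aryl group on the triazole nitrogen, 2,6-dichlorophenyl in place of 2-fluorophenyl, and nothing else in the molecule.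

Compound 3 `COc1cc2c(Oc3ccc(NC(=O)c4cn(-c5ccccc5F)nn4)cc3F)ccnc2cc1OCCCN1CCN(C)CC1` is not yet measured. It differs from compound 1 only in the basic end of the propoxy side chain: 4-methylpiperazin-1-yl in place of 4-methylpiperidin-1-yl on a saturated chain carbon, three bonds along the chain from an oxygen on an aromatic ring. Going by the values given here, no measured step touches this side chain; the step from compound 1 to compound 2 lies at the other end of the molecule and gives no guide to the size or direction of this change. Among the compounds with values here, with no bearing step, the working expectation is that compound 3 holds close to compound 1 in this assay, with a step expected of about a 1.2-fold higher number from compound 1 to compound 3 (0.08 log units; within the scatter), not beyond the scatter in either direction. Compound 3 is estimated at 250 nM, with a range of 80 nM to 800 nM.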

Compound 3, half-maximal inhibitory concentration: 300 nM
The estimate for compound 3 lay 1.2-fold (0.08 log units) below the measured number, within the range that was stated.
By their numbers in this assay, from the lowest: compounds 1 and 3 (each within the scatter of the next); then compound 2.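

In this assay, the change to 4-methylpiperazin-1-yl from 4-methylpiperidin-1-yl, on a saturated chain carbon, three bonds along the chain from an oxygen on an aromatic ring, reads as a 1.4-fold higher number from compound 1 to compound 3 (0.15 log units; within the scatter), so compound 1 and compound 3 cannot be told apart here. For the compounds shown here, this is the first reading at this place, and it shows that a ring with 2 hetero atoms and a ring with 1 hetero atom can stand here with no difference beyond the scatter, at least with 2-fluorophenyl on the triazole nitrogen; the only clear step in the set remains the aryl change, a 6.6-fold higher number from compound 1 to compound 2 (0.82 log units; beyond the scatter), at the other end of the molecule. Nothing available explains why the two rings read alike.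

Still open, on these data alone, is whether this flat reading extends to other groups at this place, such as morpholin-4-yl, an open-chain dimethylamino group or a piperazine without its methyl group, or to a shorter or longer chain. As far as these compounds go, it is also open whether 4-methylpiperazin-1-yl reads the same when 2,6-dichlorophenyl sits on the triazole nitrogen.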